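The source may hold more compounds than are shown below. What is called first, only, known or untested is meant among the compounds shown, and "the series" means these compounds.

Working notes on a small set of tetrahydropyran-linked diaryl carbinols. Of the compounds shown here, three have numbers so far. Compound 1 `COc1ccc(/C=C/C[C@H]2C[C@H]([C@H](O)c3ccc(OC)c(OC)c3)CO[C@@H]2c2ccc(OC)c(OC)c2)cc1OC` carries methoxy groups on all three aromatic rings; in a functional assay on HeLa cells (Homo sapiens) for cytotoxicity, read by WST assay, with a stated time of 48 h (a lower number here means a stronger inhibitor, a higher number a weaker inhibitor), compound 1 gives 34600 nM. Compound 2 `O[C@@H](c1ccccc1)[C@H]1CO[C@H](c2ccccc2)[C@@H](C/C=C/c2ccccc2)C1` is the unsubstituted parent, and in this assay compound 2 gives 6060 nM. Compound 3 `COc1ccc(/C=C/C[C@H]2C[C@@H]([C@@H](O)c3ccc(OC)c(OC)c3)CO[C@@H]2c2ccccc2)cc1OC` keeps methoxy groups on two of the rings; in this assay compound 3 gives 17000 nM. Compound 2 thus stands as the strongest of the three: the nearest number, that of compound 3, is higher by a margin beyond the usual scatter, and the furthest, that of compound 1, is higher by a margin also beyond the scatter.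

The next member, compound 4 `COc1ccccc1/C=C/C[C@H]1C[C@@H]([C@@H](O)c2ccccc2)CO[C@@H]1c1ccccc1`, differs from compound 2 in a single place: methoxy in place of hydrogen on an aromatic carbon, on an aromatic carbon of a six-membered aromatic ring of carbon only, ortho to a large group. Among the compounds with values here, no directly comparable pair among the measured compounds exists, so the size of the step is open. The measured methoxy-bearing compounds 1 and 3 are weaker than compound 2, but they differ in several places at once. The step from compound 2 to compound 4 is therefore expected to be small, around a 1.3-fold higher number from compound 2 to compound 4 (0.12 log units; within the scatter), not clearly beyond the scatter. For compound 4 the number in this assay is estimated at 8000 nM, within 3000 nM to 22000 nM.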

Compound 4, half-maximal inhibitory concentration: 14700 nM
For compound 4 the middle estimate is 1.8-fold (0.26 log units) below the measured one; low and high end bracket the measured number.
By their numbers in this assay, from the lowest: compound 2; then compounds 4 and 3 (each within the scatter of the next); then compound 1.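

In this assay, within the data shown here, this is the first step that changes a single place: methoxy in place of hydrogen on an aromatic carbon, ortho to a large group, turns the 2-phenylethenyl arm into 2-(2-methoxyphenyl)ethenyl and gives a 2.4-fold higher number from compound 2 to compound 4 (0.38 log units; beyond the scatter) as a modest change. Although modest, the step lies beyond the scatter, so at this position the added methoxy goes with a weaker number rather than leaving it unchanged. Among these compounds, compound 1 and compound 3 also carry methoxy groups, but each differs from compound 2 in several places, so only this pair isolates one methoxy at one place, and no measurement at hand bears on the reason for the step.

Going by these compounds, whether another group at this same place, such as hydroxyl, fluorine or an amine, would move the number in the same direction and by a similar size remains open. Among the compounds shown here, the methoxy groups on the other rings have no single-place step of their own, so their share in the numbers of compound 1 and compound 3 cannot be read.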